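Weak hydrazone series: dimethoxy swap on the aryl group

This account rests on a few compounds, and the source may have more. Where it says the series, first, only, none or still open, it means among the compounds named here.

Compound 1 `O=C(Cc1csc2nc(-c3ccc(Br)cc3)cn12)N/N=C/c1ccccc1` gives > 100000 nM in a functional assay on SK-MEL-2 cells (Homo sapiens) for inhibition, read by sulforhodamine B assay, with a stated time of 48 h (on this read-out higher numbers stand for weaker inhibition of growth and lower numbers for stronger inhibition of growth), and this is a limit of the assay, not a number. Among the compounds with values here, compound 2 `O=C(Cc1csc2nc(-c3ccc(Br)cc3)cn12)N/N=C/c1ccc(O)cc1` gives 95500 nM in this assay, the only actual number so far. Within the data shown here, only one measured step exists, hydroxy in place of hydrogen on an aromatic carbon: an at least 1.0-fold lower number from compound 1 to compound 2 (0.01 log units; that floor lies within the scatter). Compound 1 supplies one end of that step: the limit of > 100000 nM in this assay, at which 1 of the 2 values shown sits. The size of the step is therefore poorly defined.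

Compound 3 `COc1cccc(OC)c1/C=N/NC(=O)Cc1csc2nc(-c3ccc(Br)cc3)cn12` departs from compound 2 at one place: 2,6-dimethoxyphenyl in place of 4-hydroxyphenyl on a carbon with a double bond to nitrogen. In words, 2,6-dimethoxyphenyl stands in place of 4-hydroxyphenyl on a carbon with a double bond to nitrogen. Among the measured compounds shown here, the single measured step, an at least 1.0-fold lower number from compound 1 to compound 2 (0.01 log units; that floor lies within the scatter), gives no direction for this change, so no move beyond the scatter is expected in this assay. The expected step is a 1.1-fold lower number from compound 2 to compound 3 (0.03 log units; within the scatter). A report of compound 3 as a limit alone is also expected to be quite possible. The estimated value for compound 3 is 90000 nM, with an expected range of 40000 nM to 100000 nM.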

Compound 3, concentration for total growth inhibition: > 100000 nM
Compound 3: no number, only a limit; the forecaster's own chance of this, stated with the estimate: 45%; middle value at least 1.1-fold (0.04 log units) away from the limit.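

On a carbon with a double bond to nitrogen, 2,6-dimethoxyphenyl in place of 4-hydroxyphenyl gives an at least 1.0-fold higher number from compound 2 to compound 3 (0.01 log units; that floor lies within the scatter), so this swap shows no move that can be told from the scatter, even with the hydroxy group gone and two methoxy groups in its stead. In this assay compound 3 gives > 100000 nM, which is a limit of the assay and not a number. The steps with both ends at a limit cannot be read, and compound 2 remains the only compound with an actual number, so the three aryl groups at this position do not yet separate from one another: the limit of > 100000 nM in this assay, at which 2 of the 3 values shown sit.

From the compounds shown here alone, whether an amine or a carboxylic acid on this aryl group would give a number clearly below that of compound 2 stays open. Also open is whether a change elsewhere on the shared core, such as replacing the bromine with a hydrogen or a methoxy group, would move this assay at all, and the compounds shown say nothing on either point.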